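The compounds below may be only part of what the source reports. "The series", "measured", "known", "first", "only" and "open" are said of these compounds alone.

Values in a functional assay on KB cells (Homo sapiens) for antiproliferative activity, read by sulforhodamine B assay, with a stated time of 3 days; on this read-out lower numbers stand for an effect already at smaller amounts and higher numbers for an effect only at larger amounts of compound:
- compound 1 `CCC1=C(O)c2c(oc(-c3ccc(C)c(C)c3)cc2=O)C(CC)(CC)C1=O`: 35.5 uM
- compound 2 `CCC1=C(O)c2c(oc(-c3cc(C)c(OC)cc3C)cc2=O)C(CC)(CC)C1=O`: 36.6 uM
- compound 3 `CCC1=C(O)c2c(oc(-c3cc(C)c(O)c(C)c3)cc2=O)C(CC)(CC)C1=O`: 18.3 uM

The three compounds share one core and differ only in the aryl group. Compound 3 lies within the scatter of both compound 1 and compound 2, so this assay gives no order among these three.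

The next comparison is with compound 4 `CCC1=C(O)c2c(oc(-c3cc(C)ccc3C)cc2=O)C(CC)(CC)C1=O`, which has 2,5-dimethylphenyl in place of 4-hydroxy-3,5-dimethylphenyl on an aromatic carbon.

For the measured compounds named here, only one measured step bears directly on this change. It is a 1.9-fold lower number from compound 1 to compound 3 (0.29 log units; within the scatter), which brought in the group that now leaves. That step is small, and it gives no firm sign that this group matters in the assay. Going by the values given here, no measured pair isolates the entering group. Among the measured compounds, the aryl group of compound 2 looks most like it, and compound 2 gives 36.6 uM.

The expectation is therefore a value near those of compound 1 and compound 2, with no step beyond the scatter. The estimated step is a 1.7-fold higher number from compound 3 to compound 4 (0.24 log units; within the scatter).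

For compound 4 the estimated value is 32 uM, with an expected range from 16 uM to 65 uM.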

Compound 4, concentration for half-maximal effect: 14.5 uM
Compound 4: middle estimate off by 2.2-fold (0.34 log units), on the high side; the measured number lies below the stated range.
By their numbers in this assay, from the lowest: compounds 4, 3, 1 and 2 (each within the scatter of the next, the first and the last beyond it).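

In this assay, the hydroxyl of the 4-hydroxy-3,5-dimethylphenyl group is not required for activity at this position: 2,5-dimethylphenyl, with no hydrogen-bond donor or acceptor, replaces it with a 1.3-fold lower number from compound 3 to compound 4 (0.10 log units; within the scatter). For the compounds shown here, the aryl group now also yields the first steps beyond the scatter, both modest: hydrogen in place of methoxy gives a 2.5-fold lower number from compound 2 to compound 4 (0.40 log units; beyond the scatter), and 2,5-dimethylphenyl in place of 3,4-dimethylphenyl gives a 2.4-fold lower number from compound 1 to compound 4 (0.39 log units; beyond the scatter). The substitution on this aryl group therefore registers in the assay, if only weakly, but no simple order by substituent follows, since compound 3 stays within the scatter of compound 1, compound 2 and compound 4 alike.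

No measurement accompanying these values speaks to the origin of these steps. Still open, as far as these compounds go, is whether the 2,5-dimethylphenyl pattern keeps its value when an amine or a carboxylic acid is added to the aryl group, and whether the differences between these aryl groups persist when the ethyl groups on the shared core are replaced by a longer chain.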